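Cytotoxicity notes: 4-methoxyphenyl in place of 3-nitrophenyl

The source may report more compounds than this note shows. Statements on the series, on what has been measured and on what is new or still open speak of the compounds shown alone.

- compound 1 `CNC(=O)c1cc(Oc2ccc(C3=NNC(c4ccc(C#N)cc4)C3)cc2)ccn1`: "not determined" (no result reported)
- compound 2 `CNC(=O)c1cc(Oc2ccc(C3=NNC(c4ccc([N+](=O)[O-])cc4)C3)cc2)ccn1`: "not determined" (no result reported)
- compound 3 `CNC(=O)c1cc(Oc2ccc(C3=NNC(c4cccc([N+](=O)[O-])c4)C3)cc2)ccn1`: 35400 nM

Among the compounds with values here, in a functional assay on MCF7 cells (Homo sapiens) for cytotoxicity, read by MTT assay, with a stated time of 72 h (a higher number here means a weaker inhibitor, a lower number a stronger inhibitor), compound 3 holds the only number, so it cannot yet be ranked against anything. Compound 1 and compound 2 offer no result for comparison.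

The next compound is compound 4 `CNC(=O)c1cc(Oc2ccc(C3=NNC(c4ccc(OC)cc4)C3)cc2)ccn1`, which has 4-methoxyphenyl in place of 3-nitrophenyl on a saturated ring carbon.

Within the data shown here, no step between measured compounds is available to size this change, and the direction is equally open. Without such a guide, no move beyond the scatter is expected in this assay. Among the measured compounds shown here, the expected step is a 1.2-fold lower number from compound 3 to compound 4 (0.07 log units; within the scatter), an estimate that stays within that scatter and rests only on the single value of compound 3 35400 nM. The estimate for compound 4 is 30000 nM, with an expected range from 10000 nM to 80000 nM.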

Compound 4, half-maximal inhibitory concentration: 11000 nM
Beside the measured number, compound 4's estimate is 2.7-fold (0.44 log units) above it; measured number inside the range.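

In this assay, within the data shown here, 4-methoxyphenyl in place of 3-nitrophenyl on the saturated ring carbon gives a 3.2-fold lower number from compound 3 to compound 4 (0.51 log units; beyond the scatter), the first readable step, and it shows that the group at this position can move the result beyond the scatter. The two groups differ both in the substituent and in its place on the phenyl ring, so this single step does not separate those two changes. No available measurement offers an explanation for the shift.

Steps involving compound 1 and compound 2 cannot be read, leaving the 4-cyanophenyl and 4-nitrophenyl groups unplaced relative to compound 3 and compound 4. Also open, as far as these compounds go, is how an amine or a carboxylic acid on this phenyl ring, or a longer alkoxy chain in place of methoxy, would behave at this position.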